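The compounds below may be only part of what the source reports. "The series", "measured", "known", "first", "only" and "open" are said of these compounds alone.

In a functional assay on A549 cells (Homo sapiens) for cytotoxicity, read by MTT assay, with a stated time of 48 h (a higher number here means a weaker inhibitor, a lower number a stronger inhibitor), compound 1 `COc1cc([C@H]2C[C@]2(CO)C(=O)NCc2ccc(C)cc2)cc(OC)c1OC` gives 60700 nM, and its mirror image, compound 2 `COc1cc([C@@H]2C[C@@]2(CO)C(=O)NCc2ccc(C)cc2)cc(OC)c1OC`, gives 46300 nM. The two numbers lie within the usual scatter, so compound 2 stands level with compound 1. Within the data shown here, the only measured step, a 1.3-fold lower number from compound 1 to compound 2 (0.12 log units; within the scatter), reflects the fact that compounds 1 and 2 differ only in the configuration as drawn and does not touch the group on the amide nitrogen.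

Compound 3 `COc1cc([C@@H]2C[C@@]2(CO)C(=O)Nc2ccccc2Cl)cc(OC)c1OC` keeps the core and configuration of compound 2 but carries 2-chlorophenyl in place of 4-methylbenzyl on an amide-type nitrogen. Among the measured compounds shown here, no measured step shows what such a swap does, so the small size of a 1.3-fold lower number from compound 1 to compound 2 (0.12 log units; within the scatter) gives only a weak guide, and no direction can be argued. A change beyond the scatter is therefore not expected, though the uncertainty is wide. The expected step is a 1.0-fold lower number from compound 2 to compound 3 (0.01 log units; within the scatter). In this assay, compound 3 is estimated at 45000 nM, within an expected range of 15000 nM to 100000 nM.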

Compound 3, half-maximal inhibitory concentration: 11400 nM
Compound 3: middle estimate off by 3.9-fold (0.60 log units), on the high side; the measured number lies below the stated range.
By their numbers in this assay, from the lowest: compound 3; then compounds 2 and 1 (each within the scatter of the next).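

The group on the amide nitrogen matters in this assay in a way the mirror-image pair could not show: 2-chlorophenyl in place of 4-methylbenzyl gives a 4.1-fold lower number from compound 2 to compound 3 (0.61 log units; beyond the scatter) and so moves the number beyond the scatter, which the change of configuration did not do. This swap alters several things at once, going from benzyl to phenyl and from methyl to chlorine, so the step belongs to the whole swap and not to any one part of it. Nothing given here accounts for the step.

Going by these compounds, it remains open whether the lower number follows the chlorine, the phenyl attached directly to the amide nitrogen, or only the two together, which plain phenyl and 2-chlorobenzyl would separate. Also open, on these data alone, is how a group carrying an amine or a carboxylic acid would behave at this nitrogen.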